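This account rests on a few compounds, and the source may have more. Where it says the series, first, only, none or still open, it means among the compounds named here.

Three measured compounds share one core. In an assay on cell membranes for displacement of a labelled ligand from adenosine receptor A1 (Rattus norvegicus) (a higher number here means a weaker inhibitor, a lower number a stronger inhibitor), compound 3 `CCn1c(=O)c2c(nc(Cc3ccccc3)n2C)n(Cc2ccco2)c1=O` gives 28.8 nM, the lowest of the three numbers. In this assay compound 2 `O=c1c2[nH]c(Cc3cccs3)nc2n(Cc2ccco2)c(=O)n1CC1CC1` gives 347 nM and compound 1 `CC(C)Cn1c(=O)c2[nH]c(Cc3ccccc3)nc2n(Cc2ccco2)c1=O` gives 490 nM; both numbers stand beyond the scatter from compound 3, so compound 3 is the strongest inhibitor measured here. Compound 4 `CCn1c(=O)c2c(nc(Cc3ccco3)n2C)n(Cc2ccco2)c1=O` has not yet been measured. It differs from compound 3 by furan-2-yl in place of phenyl on a saturated chain carbon bound to an aromatic carbon. Among the compounds with values here, no measured pair isolates this exchange, so there is no earlier step to lean on. The expected step of a 1.6-fold higher number from compound 3 to compound 4 (0.19 log units; within the scatter) is small, a mild weakening that may not exceed the scatter. Compound 4 is therefore expected near 45 nM, with a range from 15 nM to 140 nM.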

Compound 4, inhibition constant: 107 nM
Beside the measured number, compound 4's estimate is 2.4-fold (0.38 log units) below it, and the stated range covers the measured number.
By their numbers in this assay, from the lowest: compound 3; then compound 4; then compounds 2 and 1 (each within the scatter of the next).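

In this assay, furan-2-yl in place of phenyl on a saturated chain carbon bound to an aromatic carbon gives a 3.7-fold higher number from compound 3 to compound 4 (0.57 log units; beyond the scatter). Within the data shown here, this is the first exchange in this set read at a single place, and it shows that this position does respond to the ring it carries, though the step is only modest. Nothing available here accounts for the rise. Still open, from the compounds shown here alone, is how a cyclohexyl or pyridin-2-yl group would behave at this place. The same exchange may also give a different step in compounds lacking the methyl group of compound 3.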